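This account rests on a few compounds, and the source may have more. Where it says the series, first, only, none or still open, it means among the compounds named here.

Three compounds have been measured in a functional assay on VCaP cells (Homo sapiens) for antiproliferative activity, read by propidium iodide staining, with a stated time of 96 h; a lower number here means a stronger inhibitor, a higher number a weaker inhibitor:

Compound 1 `CC(O)(COc1cccc(S(F)(F)(F)(F)F)c1)C(=O)Nc1ccc(S(F)(F)(F)(F)F)cc1` gives 11400 nM.
Compound 2 `CC(O)(COc1cccc(C(F)(F)F)c1)C(=O)Nc1ccc(S(F)(F)(F)(F)F)cc1` gives 24700 nM.
Compound 3 `CC(O)(COc1ccc(S(F)(F)(F)(F)F)cc1)C(=O)Nc1cccc(S(F)(F)(F)(F)F)c1` gives 8000 nM.

Compound 2 differs from compound 1 by one change, (a group of 4 heavy atoms (1 carbon, 3 fluorine; no ring) in place of a group of 6 heavy atoms (5 fluorine, 1 sulfur; no ring), on an aromatic carbon), and that change brought a 2.2-fold higher number from compound 1 to compound 2 (0.34 log units; beyond the scatter). Compound 3 and compound 1 hold the same atoms joined differently; the difference between the two cores is not broken down here, and their two numbers in this assay lie within the scatter of each other, so no order between them is claimed. Compound 2 sits beyond the scatter from compound 3.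

Compound 4 `CC(O)(COc1ccc(C(F)(F)F)cc1)C(=O)Nc1cccc(S(F)(F)(F)(F)F)c1` is not yet measured. It differs from compound 3 by a group of 4 heavy atoms (1 carbon, 3 fluorine; no ring) in place of a group of 6 heavy atoms (5 fluorine, 1 sulfur; no ring), on an aromatic carbon. This is the same kind of change as from compound 1 to compound 2, not the same: there the group sits meta to a large group, here para to a large group. Going by the values given here, compound 4 is expected to show a 2.1-fold higher number from compound 3 to compound 4 (0.33 log units; beyond the scatter) because a 2.2-fold higher number from compound 1 to compound 2 (0.34 log units; beyond the scatter) is the only measured guide to this change. Compound 4 is therefore estimated at 17000 nM, likely between 9000 nM and 35000 nM.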

Compound 4, half-maximal inhibitory concentration: 13300 nM
Beside the measured number, compound 4's estimate is 1.3-fold (0.11 log units) above it; the range from low to high includes it.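

In this assay, trifluoromethyl in place of the group of 5 fluorine and 1 sulfur gives a 1.7-fold higher number from compound 3 to compound 4 (0.22 log units; within the scatter), so on this core the change does not separate the two compounds. Set beside the earlier step, the new one cannot be told apart from it in size: the same change on two cores in this assay, a 2.2-fold higher number (0.34 log units; beyond the scatter) from compound 1 to compound 2 and a 1.7-fold higher number (0.22 log units; within the scatter) from compound 3 to compound 4, 1.3-fold (0.12 log units) apart, within the scatter of two such steps. This shows that the change carried over between these two cores with no detectable difference in the size of its step, but it rests on a single pair per core, one step beyond the scatter and the other within it, and it does not show that the step would hold on any other core or at any other place on the ring.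

The compounds shown leave open how a chlorine, a nitrile or a methoxy group at the same place would compare with trifluoromethyl in this assay. They also leave open what an amine or a carboxylic acid would give in place of the hydroxyl group on the shared chain.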